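The source may report more compounds than this note shows. Statements on the series, on what has been measured and on what is new or still open speak of the compounds shown alone.

Of the compounds shown here, two have so far been tested in a functional assay on SH-SY5Y cells (Homo sapiens) for cytotoxicity, read by MTT assay, with stated times of 8 h, 30 min and 12 h, tested at 5 uM; a lower number here means a weaker effect, a higher number a stronger effect of the compound at the concentration tested. Compound 2 `COc1ccc(CN2C(=O)CC[C@H]2C(=N)NCc2ccc(O)cc2)cc1` gives 26.6%. Among the compounds with values here, compound 1 `COc1ccc(CNC(=N)[C@@H]2CCC(=O)N2Cc2ccc([N+](=O)[O-])cc2)cc1`, the only other compound measured, gives 35.2%, and the two numbers lie within the usual scatter of each other. Compound 3 `COc1ccc(CNC(=N)[C@@H]2CCC(=O)N2Cc2ccc(OC)cc2)cc1` differs from compound 2 by one small change: methyl in place of hydrogen on an oxygen on an aromatic ring. Within the data shown here, no measured pair shows what this change does, so no step beyond the scatter is expected in either direction. Compound 3 is therefore expected to give about 30%, between 15% and 45%. The expected step is a number 3.4 percentage points higher from compound 2 to compound 3 (within the scatter).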

Compound 3, a percentage reported as activity, at one concentration (the size of the read-out at that concentration, not a potency): 33.6%
Beside the measured number, compound 3's estimate is 3.6 percentage points below it; measured number inside the range.
By their numbers in this assay, from the lowest: compounds 2, 3 and 1 (each within the scatter of the next).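

In this assay, within the data shown here, a number 7 percentage points higher from compound 2 to compound 3 (within the scatter) is the first measured reading of methyl in place of hydrogen on this oxygen, which turns 4-hydroxybenzyl into 4-methoxybenzyl. The step of a number 1.6 percentage points lower from compound 1 to compound 3 (within the scatter) adds a second change, methoxy in place of nitro on an aromatic carbon, so neither change moves the read-out beyond the usual scatter. Nothing available gives a reason for this result. On these data alone, whether an amine or a carboxylic acid on that aromatic carbon would give a step beyond the scatter stays open. So does the effect of a longer chain on the oxygen, such as ethyl.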